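The compounds below may be only part of what the source reports. "The series", "measured", "known", "first", "only" and "open" are said of these compounds alone.

Three compounds share one core and differ only in the group on a saturated chain carbon bound to an aromatic carbon. Compound 1 `O=C(O)c1ccccc1-c1ccc(CCc2ncc(CC3CCCCC3)[nH]2)cc1` carries cyclohexyl there, and in an in vitro functional assay on cells for agonist activity at Bombesin receptor subtype-3 (Homo sapiens), read by luminescence and calcium flux (on this read-out lower numbers stand for an effect already at smaller amounts and higher numbers for an effect only at larger amounts of compound), compound 1 gives 41 nM. Compound 2 `O=C(O)c1ccccc1-c1ccc(CCc2ncc(CC3CCC3)[nH]2)cc1` carries cyclobutyl, and in this assay compound 2 gives 588 nM. Compound 3 `CC(C)CCc1cnc(CCc2ccc(-c3ccccc3C(=O)O)cc2)[nH]1` carries isobutyl, and in this assay compound 3 gives 119 nM, the second highest of the three numbers: a 2.9-fold higher number from compound 1 to compound 3 (0.46 log units; beyond the scatter), while a 4.9-fold lower number from compound 2 to compound 3 (0.69 log units; beyond the scatter).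

Compound 4 `O=C(O)c1ccccc1-c1ccc(CCc2ncc(Cc3cccc(Cl)c3)[nH]2)cc1` has not yet been measured. Its difference from compound 3 is 3-chlorophenyl in place of isobutyl on a saturated chain carbon bound to an aromatic carbon. Both steps at this position bear on the change: a 14-fold higher number from compound 1 to compound 2 (1.16 log units; beyond the scatter), and a 2.9-fold higher number from compound 1 to compound 3 (0.46 log units; beyond the scatter). Among the measured compounds, cyclohexyl stands with the lowest number and cyclobutyl with the highest, and the entering 3-chlorophenyl brings a ring where isobutyl had none, as the counted difference shows. On that basis a modest step toward a lower number is expected for compound 4. The estimate for compound 4 in this assay is 60 nM, with an expected range from 20 nM to 200 nM. This estimate is expected to amount to a 2.0-fold lower number from compound 3 to compound 4 (0.30 log units; within the scatter).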

Compound 4, half-maximal effective concentration: 825 nM
Beside the measured number, compound 4's estimate is 14-fold (1.14 log units) below it; the measured number lies above the stated range.
By their numbers in this assay, from the lowest: compound 1; then compound 3; then compounds 2 and 4 (each within the scatter of the next).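

At this position, a ring in the entering group does not by itself bring a lower number: 3-chlorophenyl adds a six-membered aromatic ring where isobutyl had none, yet the step runs upward (a 6.9-fold higher number from compound 3 to compound 4 (0.84 log units; beyond the scatter)). The 3-chlorophenyl group cannot be told apart from cyclobutyl (a 1.4-fold higher number from compound 2 to compound 4 (0.15 log units; within the scatter)) and stands far from cyclohexyl (a 20-fold higher number from compound 1 to compound 4 (1.30 log units; beyond the scatter)), so two six-membered rings at this place, one saturated and one aromatic and chlorinated, give widely separated results in this assay, and a group with a ring can now lie at either end of the series. Nothing measured here accounts for these differences.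

Going by these compounds, whether the higher number of compound 4 goes with the chlorine or with the aromatic ring itself remains open, and an unsubstituted phenyl group at this place would separate the two. Also open is where a cyclopentyl group, a longer chain or an amine would fall among the groups shown, and whether the wide gap between cyclobutyl and cyclohexyl reflects a steady trend with ring size.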